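A Chloro Atom Added to the Benzoyl Group

A few compounds are considered here, and "the series" means these few. Any claim that something is new, unique, unknown or untested is made for them only; others in the source may bear on it.

Compound 3 `Cc1ccc(OCC(=O)NNC(=O)c2cc3ccccc3oc2=O)c(C(=O)c2ccccc2)c1` ends in a plain benzoyl group. In a functional assay on DLA cells (Mus musculus) for cytotoxicity, read by trypan blue exclusion, with a stated time of 48 h (on this read-out lower numbers stand for stronger inhibition and higher numbers for weaker inhibition), compound 3 gives 89100 nM, the highest of the three numbers measured, which here means the weakest inhibition. Compound 1 `COc1ccc(C(=O)c2cc(C)ccc2OCC(=O)NNC(=O)c2cc3ccccc3oc2=O)cc1` gives 43500 nM in this assay, and compound 2 `Cc1ccc(OCC(=O)NNC(=O)c2cc3ccccc3oc2=O)c(C(=O)c2cccc(Cl)c2)c1` gives 68600 nM. The move a 2.0-fold higher number from compound 1 to compound 3 (0.31 log units; beyond the scatter) is modest, while a 1.3-fold higher number from compound 2 to compound 3 (0.11 log units; within the scatter) and a 1.6-fold higher number from compound 1 to compound 2 (0.20 log units; within the scatter) both stay within the scatter.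

Compound 4 `Cc1ccc(OCC(=O)NNC(=O)c2cc3ccccc3oc2=O)c(C(=O)c2ccccc2Cl)c1` differs from compound 3 by one change: chloro in place of hydrogen on an aromatic carbon. The closest measured comparison is a 1.3-fold higher number from compound 2 to compound 3 (0.11 log units; within the scatter), where a chloro atom left the benzoyl group and the two numbers lay within the scatter of each other. Adding a chloro atom, here ortho to a large group, is therefore expected to give only a small step toward a lower number, probably not beyond the scatter. The expected step is a 1.3-fold lower number from compound 3 to compound 4 (0.10 log units; within the scatter). Compound 4 is estimated to give 70000 nM in this assay, with a range from 35000 nM to 140000 nM.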

Compound 4, half-maximal inhibitory concentration: 54800 nM
Compound 4: middle estimate off by 1.3-fold (0.11 log units), on the high side; the range from low to high includes it.
By their numbers in this assay, from the lowest: compounds 1, 4, 2 and 3 (each within the scatter of the next, the first and the last beyond it).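

Placing a chloro atom on the benzoyl ring, ortho to a large group, leaves the number in this assay within the scatter of the plain benzoyl compound (a 1.6-fold lower number from compound 3 to compound 4 (0.21 log units; within the scatter)), so this position accepts the atom without a clear shift. The placement of the chloro atom cannot be told apart here either (a 1.3-fold lower number from compound 2 to compound 4 (0.10 log units; within the scatter)), and 2-chlorophenyl also stays within the scatter of 4-methoxyphenyl (a 1.3-fold higher number from compound 1 to compound 4 (0.10 log units; within the scatter)), so compound 4 sits within the scatter of both compounds that lie furthest apart. No other measurement bears on why these numbers fall as they do.

From the compounds shown here alone, it remains open whether a larger change at this position, such as an amine or a carboxylic acid on the ring, would move the number beyond the scatter. A longer chain in place of the chloro atom is equally untested by the compounds shown.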